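A few compounds are considered here, and "the series" means these few. Any claim that something is new, unique, unknown or untested is made for them only; others in the source may bear on it.

In a functional assay on MCF7 cells (Homo sapiens) for inhibition, in the presence of a further agent that is not named here (on this read-out lower numbers stand for stronger inhibition and higher numbers for weaker inhibition), compound 3 `Nc1ccc(-c2cc(=O)c3c(N)c(F)ccc3o2)cc1` gives 130 nM. This lies within the scatter of compound 2 `Nc1c(F)cc(-c2cc(=O)c3c(N)c(F)cc(F)c3o2)cc1F` at 89 nM. Compound 1 `Nc1ccc(-c2cc(=O)c3c(N)c(Cl)cc(Cl)c3o2)cc1`, at 610 nM, has a number beyond the scatter above that of compound 3. The next compound, compound 4 `Nc1ccc(-c2cc(=O)c3c(N)c(Cl)ccc3o2)cc1`, carries chloro in place of fluoro on an aromatic carbon, ortho to an amino group: chloro in place of fluoro on an aromatic carbon. No measured pair differs in only one place, so the size of this step is not shown directly. The closest guide is compound 1, which also carries chloro on the shared core and gives 610 nM, but it differs from compound 3 in more than one place. A move toward weaker inhibition is therefore expected, though only part of the way to compound 1 and perhaps not far beyond the scatter. The expected change is a 1.8-fold higher number from compound 3 to compound 4 (0.27 log units; within the scatter). Compound 4 is estimated at 240 nM, with an expected range from 100 nM to 600 nM.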

Compound 4, half-maximal inhibitory concentration: > 10000 nM
Compound 4 was reported as a limit; the forecaster's own chance of this, stated with the estimate: 3%; middle value at least 41-fold (1.61 log units) from the limit.
By their numbers in this assay, from the lowest: compounds 2 and 3 (each within the scatter of the next); then compound 1. At a limit, above all of these: compound 4.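

Chloro in place of fluoro on this aromatic carbon, ortho to an amino group, gives an at least 76-fold higher number from compound 3 to compound 4 (1.88 log units; beyond the scatter) in this assay, so this single-atom exchange separates a compound with a measurable value from one without. The value for compound 4 is a limit of the assay and not a number: the limit of > 10000 nM in this assay, at which 1 of the 4 values shown sits. Compound 1 carries the same chloro plus a further chloro on the shared core, and hydrogen in place of that further chloro gives an at least 16-fold higher number from compound 1 to compound 4 (1.21 log units; beyond the scatter), so chloro at this position does not by itself remove measurable inhibition.

The compounds shown leave open how hydrogen, methyl or methoxy at this position would read. They also leave open whether fluoro in place of the further chloro of compound 1 would behave as that chloro does.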